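From carboxy to cyclopropylcarbamoyl on a shared core

A few compounds are considered here, and "the series" means these few. Any claim that something is new, unique, unknown or untested is made for them only; others in the source may bear on it.

Measured in a functional assay on MDA-MB-231 cells (Homo sapiens) for cytotoxicity, read by MTT assay, with a stated time of 24 h; a higher number here means a weaker inhibitor, a lower number a stronger inhibitor:
Compound 1 `Fc1ccc(-c2nc3cccnc3n2C2CCCC2)cc1`: 500 nM
Compound 2 `c1ccc(Oc2ccc(-c3nc4cccnc4n3C3CCCC3)cc2)cc1`: > 10000 nM, a limit of the assay and not a number
Compound 3 `O=C(O)c1ccc(-c2nc3cccnc3n2C2CCCC2)cc1`: 600 nM

Compound 3 sits level with the fluoro compound, as replacing fluoro by carboxy gave a 1.2-fold higher number from compound 1 to compound 3 (0.08 log units; within the scatter). It lies far from the phenoxy compound, with an at least 16-fold lower number from compound 2 to compound 3 (1.22 log units; beyond the scatter).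

Compound 4 `O=C(NC1CC1)c1ccc(-c2nc3cccnc3n2C2CCCC2)cc1` carries cyclopropylamino in place of hydroxy on a carbonyl carbon. For the measured compounds named here, no measured step changes this carbonyl carbon directly, so only the swaps on the aromatic carbon bear on it, and they pull apart. The carboxy swap was silent, while phenoxy in place of fluoro gave an at least 20-fold higher number from compound 1 to compound 2 (1.30 log units; beyond the scatter), which leaves some risk toward a higher number.

In this assay the expected change is a 1.7-fold higher number from compound 3 to compound 4 (0.22 log units; within the scatter), so no shift beyond the scatter is the central expectation. For compound 4 the estimated value is 1000 nM, with an expected range of 300 nM to 5000 nM.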

Compound 4, half-maximal inhibitory concentration: 115 nM
Beside the measured number, compound 4's estimate is 8.7-fold (0.94 log units) above it, outside the stated range (below it).
By their numbers in this assay, from the lowest: compound 4; then compounds 1 and 3 (each within the scatter of the next). At a limit, above all of these: compound 2.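

In this assay, the carbonyl carbon proves to be a place that responds, although carboxy and fluoro on the aromatic carbon had read level: cyclopropylamino in place of hydroxy gave a 5.2-fold lower number from compound 3 to compound 4 (0.72 log units; beyond the scatter), and cyclopropylcarbamoyl in place of fluoro gave a 4.3-fold lower number from compound 1 to compound 4 (0.64 log units; beyond the scatter). Among the groups shown on that aromatic carbon, cyclopropylcarbamoyl is thus the first to bring the number down beyond the scatter, and the comparison with phenoxy reads an at least 86-fold lower number from compound 2 to compound 4 (1.93 log units; beyond the scatter). Compound 2 enters that comparison only through a limit of the assay and not a number: the limit of > 10000 nM in this assay, at which 1 of the 4 values shown sits.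

The compounds shown do not separate the three-membered ring from the amide hydrogen. From the compounds shown here alone, how a methylamino or a cyclobutylamino group on this carbonyl carbon would read stays open.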